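Indole Amide in Place of Naphthalene Amide

This account rests on a few compounds, and the source may have more. Where it says the series, first, only, none or still open, it means among the compounds named here.

Compound 1, `CN1[C@@H]2c3[nH]c4ccccc4c3C[C@H]1[C@H](C#N)N1[C@@H](CN3C(=O)c4ccccc4C3=O)c3[nH]c4ccccc4c3C[C@@H]21`: 40 nM
Compound 2, `CN1[C@@H]2c3[nH]c4ccccc4c3C[C@H]1[C@H](C#N)N1[C@@H](CNC(=O)c3ccc4ccccc4c3)c3[nH]c4ccccc4c3C[C@@H]21`: 420 nM

Of the two compounds measured in a functional assay on HCT-116 cells (Homo sapiens) for cytotoxicity, read by MTT assay, with a stated time of 72 h (on this read-out higher numbers stand for weaker inhibition and lower numbers for stronger inhibition), compound 2 gives the highest number, 420 nM, while compound 1 gives 40 nM, a gap beyond the scatter. Compound 3 `CN1[C@@H]2c3[nH]c4ccccc4c3C[C@H]1[C@H](C#N)N1[C@@H](CNC(=O)c3cc4ccccc4[nH]3)c3[nH]c4ccccc4c3C[C@@H]21` differs from compound 2 in one place: 1H-indol-2-yl in place of naphthalen-2-yl on a carbonyl carbon. Among the measured compounds shown here, no step between measured compounds of this kind is available, so only a cautious expectation can be made. In this assay the step is expected to be a 1.4-fold lower number from compound 2 to compound 3 (0.15 log units; within the scatter), with no clear direction and likely within the scatter. Compound 3 is therefore estimated at 300 nM, with a range from 100 nM to 1500 nM.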

Compound 3, half-maximal inhibitory concentration: 880 nM
Compound 3: the middle estimate sits 2.9-fold (0.47 log units) below what was measured; the measured number falls inside the stated range.
By their numbers in this assay, from the lowest: compound 1; then compound 2; then compound 3.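

In this assay the group on this carbonyl carbon proves not to be freely exchangeable, since 1H-indol-2-yl in place of naphthalen-2-yl gives a 2.1-fold higher number from compound 2 to compound 3 (0.32 log units; beyond the scatter) and so a modest loss. The replacement of the whole group carried by compound 1 costs far more, with a 22-fold higher number from compound 1 to compound 3 (1.34 log units; beyond the scatter) as the large step on that saturated chain carbon. Nothing available explains either step.

Still open, going by these compounds, is how a plain phenyl on this carbonyl carbon would read. Also open, on these data alone, is whether a methyl on the indole nitrogen would recover the number of compound 2.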